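This account rests on a few compounds, and the source may have more. Where it says the series, first, only, none or still open, it means among the compounds named here.

Compound 2 `CN(C)CCCCOC(=O)Nc1ccc(Cn2nc(-c3ccc(C#N)cc3)c3ccccc3c2=O)cc1` and compound 1 `CN(C)CCCCN(C(=O)O)c1cccc(Cn2nc(-c3ccc(F)cc3)c3ccccc3c2=O)c1` were both tested in an ADME assay on Huh-7 cells (Homo sapiens) for cytotoxicity, read by MTT assay, with a stated time of 48 h; a lower number here means that less compound is tolerated, a higher number that more compound is tolerated. Compound 2 gives 37000 nM, the higher of the two numbers, while compound 1 gives 8510 nM, a gap beyond the usual scatter. Compound 3 `CN(C)CCCCOC(=O)Nc1ccc(Cn2nc(-c3ccccc3C(F)(F)F)c3ccccc3c2=O)cc1` differs from compound 2 in one place: 2-(trifluoromethyl)phenyl in place of 4-cyanophenyl on an aromatic carbon. For the measured compounds named here, no measured pair shows this change, so only a modest shift, in either direction or none beyond the scatter, is expected in this assay; the estimated step is a 1.2-fold lower number from compound 2 to compound 3 (0.09 log units; within the scatter). Compound 3 is expected to give about 30000 nM, within a range from 10000 nM to 80000 nM.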

Compound 3, half-maximal cytotoxic concentration: 35700 nM
For compound 3 the middle estimate is 1.2-fold (0.08 log units) below the measured one; the measured number falls inside the stated range.
By their numbers in this assay, from the lowest: compound 1; then compounds 3 and 2 (each within the scatter of the next).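

Placing 2-(trifluoromethyl)phenyl in place of 4-cyanophenyl on the aromatic carbon next to the ring nitrogen gives a 1.0-fold lower number from compound 2 to compound 3 (0.02 log units; within the scatter) in this assay. At this position, then, one substituted phenyl group can replace the other with no shift beyond the scatter, even though the two groups carry different substituents at different ring positions. Nothing measured here offers an explanation for this result.

On these data alone, it remains open whether an unsubstituted phenyl, or a phenyl carrying an amine or a carboxylic acid, would behave the same way at this carbon.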